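Working notes: from compound 2 to compound 3

This account rests on a few compounds, and the source may have more. Where it says the series, first, only, none or still open, it means among the compounds named here.

Measured in a functional assay on HL-60 cells (Homo sapiens) for cytotoxicity, read by CCK-8 assay, with a stated time of 24 h (a higher number here means a weaker inhibitor, a lower number a stronger inhibitor), so far:
- compound 1 `C=CC(=O)N1C(=O)CCSc2ccccc21` gives 44800 nM
- compound 2 `C=CC(=O)N1C(=O)CC(c2ccc(-c3ccccc3)cc2)Sc2ccccc21` gives 118000 nM

Of these two numbers, compound 2 has the higher one, which makes it the weaker inhibitor of the pair, and its gap to compound 1 lies beyond the usual scatter. Still unmeasured is compound 3 `C=CC(=O)N1C(=O)CC(c2ccccc2)Sc2ccccc21`, which has hydrogen in place of phenyl on an aromatic carbon compared with compound 2 (hydrogen in place of phenyl on an aromatic carbon). Within the data shown here, the series offers no measured step between compounds that differ in one place, so any expectation here rests on thin ground. Among the measured compounds shown here, the only guide is the pair of measured numbers, with compound 1 at 44800 nM and compound 2 at 118000 nM. A modest move towards a lower number is therefore expected, near the edge of the usual scatter. In this assay the expected change is a 2.0-fold lower number from compound 2 to compound 3 (0.29 log units; within the scatter) and this remains an estimate. For compound 3 the estimated value is 60000 nM, with an expected range from 25000 nM to 130000 nM.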

Compound 3, half-maximal inhibitory concentration: 97400 nM
For compound 3 the middle estimate is 1.6-fold (0.21 log units) below the measured one; the measured number falls inside the stated range.
By their numbers in this assay, from the lowest: compound 1; then compounds 3 and 2 (each within the scatter of the next).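

In this assay, hydrogen in place of phenyl on an aromatic carbon, para to a large group, gives a 1.2-fold lower number from compound 2 to compound 3 (0.08 log units; within the scatter), so this first one-place comparison at that position shows no readable effect of the outer phenyl. The step that can be read lies elsewhere in the structure: phenyl in place of hydrogen on a saturated ring carbon gives a 2.2-fold higher number from compound 1 to compound 3 (0.34 log units; beyond the scatter), a modest change, and of the two steps it alone lies beyond the scatter. No measurement at hand bears on why either step has the size it has.

Hydrogen and phenyl are the only two substituents shown on the aromatic carbon, so it remains open whether an amine or a carboxylic acid there would also stay within the scatter of compound 3. On these data alone, it also remains open whether a methyl group or a longer chain on the saturated ring carbon would give a step like that of phenyl, or whether the step seen with phenyl is particular to that ring.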